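A Chloro Group Added to Compound 2

This account rests on a few compounds, and the source may have more. Where it says the series, first, only, none or still open, it means among the compounds named here.

Compound 1 `O=C(CCCCC1CCSS1)Nc1cccc(C(F)(F)F)c1` - 4.76%
Compound 2 `O=C(CCCCC(CCSC(=O)c1ccccc1)SC(=O)c1ccccc1)Nc1ccccc1` - 3.79%

In a functional assay on HO8910 cells (Homo sapiens) for inhibition, read by MTT assay, with a stated time of 24 h, tested at 1 ug/mL (a higher number here means more inhibition of growth at the concentration tested, a lower number less inhibition of growth), compound 2 gives 3.79% and stands within the usual scatter of compound 1 (4.76%), so these two numbers cannot be ranked. Both are small values for this read-out.

Compound 3 `O=C(CCCCC(CCSC(=O)c1ccccc1)SC(=O)c1ccccc1)Nc1ccc(Cl)cc1` is compound 2 altered in one place: chloro in place of hydrogen on an aromatic carbon. In words, chloro takes the place of hydrogen on an aromatic carbon, so phenylcarbamoyl becomes (4-chlorophenyl)carbamoyl. Among the compounds with values here, no measured pair here shows what such a change does in this assay, so no direction can be read from the data. The expectation therefore stays close to compound 2 (3.79%), with no shift beyond the scatter. The expected change is small: a number 2.2 percentage points higher from compound 2 to compound 3 (within the scatter). For compound 3 the estimated value is 6% (expected range 0% to 16%).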

Compound 3, percent growth inhibition at one concentration: 1.29%
Compound 3: middle estimate off by 4.7 percentage points, on the high side; low and high end bracket the measured number.
By their numbers in this assay, from the lowest: compounds 3, 2 and 1 (each within the scatter of the next).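

Within the data shown here, compound 2 and compound 3 form the first pair here that differs in one place, and in this assay the change gives a number 2.5 percentage points lower from compound 2 to compound 3 (within the scatter). Putting 4-chlorophenyl in place of phenyl therefore leaves the result within the usual scatter, so this position shows no readable response to chloro at the single concentration tested. Both numbers are small, which leaves little room to see any effect, and nothing available explains the result.

As far as these compounds go, it remains open whether another group at this position, such as an amine, a carboxylic acid or a longer carbon chain, would shift the number beyond the scatter. The compounds shown also leave open whether chloro elsewhere on the same ring would behave differently.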